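The source may report more compounds than this note shows. Statements on the series, on what has been measured and on what is new or still open speak of the compounds shown alone.

Compound 1 `CC/N=C(/NC#N)NCCCCn1nc(-c2ccccc2)ccc1=O`: 92 mg/kg
Compound 2 `CC/N=C(/NC#N)NCCCCn1nc(-c2ccccc2)cc(C)c1=O`: 100 mg/kg

In a functional assay on the whole organism (stomach) with Rattus norvegicus as the target (on this read-out higher numbers stand for an effect only at larger amounts of compound and lower numbers for an effect already at smaller amounts), compound 1 gives 92 mg/kg, the lowest of the two numbers shown. Compound 2 gives 100 mg/kg, so the step of a 1.1-fold higher number from compound 1 to compound 2 (0.04 log units; within the scatter) stays within the scatter and the two compounds cannot be told apart on this read-out. Compound 3 `C/N=C(\NC#N)NCCCCn1nc(-c2ccccc2)ccc1=O` differs from compound 1 in one place: a group of 6 heavy atoms (3 carbon, 3 nitrogen; no ring) in place of a group of 7 heavy atoms (4 carbon, 3 nitrogen; no ring), on an amine nitrogen. Within the data shown here, no measured step touches this part of the molecule; the only step available, a 1.1-fold higher number from compound 1 to compound 2 (0.04 log units; within the scatter), concerns an aromatic carbon elsewhere in the shared core and is itself within the scatter. With nothing in the data pointing either way, the expectation for compound 3 is a step of no change at the digits printed from compound 1 to compound 3 (within the scatter), that is, no change beyond the scatter. Compound 3 is therefore estimated at 92 mg/kg, with a range from 45 mg/kg to 190 mg/kg.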

Compound 3, dose for half-maximal effect: 32.4 mg/kg
Compound 3: middle estimate off by 2.8-fold (0.45 log units), on the high side, outside the stated range (below it).
By their numbers in this assay, from the lowest: compound 3; then compounds 1 and 2 (each within the scatter of the next).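

Changing the group on the amine nitrogen moves the number beyond the scatter (a 2.8-fold lower number from compound 1 to compound 3 (0.45 log units; beyond the scatter)), so in this assay this part of the molecule affects the dose needed, even though the change is only a group of 6 heavy atoms in place of a group of 7 heavy atoms. The earlier step, methyl in place of hydrogen on an aromatic carbon in the shared core, did not show this kind of sensitivity (a 1.1-fold higher number from compound 1 to compound 2 (0.04 log units; within the scatter)). No measurement here explains why the step on the amine nitrogen occurs.

Going by these compounds, a single step gives a direction for this one pair, not a trend, so it remains open how a hydrogen or a longer chain, such as propyl, on that nitrogen would read. On these data alone, it also remains open whether the lower number of compound 3 would hold with the aromatic methyl of compound 2 added.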